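The source may hold more compounds than are shown below. What is called first, only, known or untested is meant among the compounds shown, and "the series" means these compounds.

Of the compounds shown here, three sharing one core have been tested in a functional assay on HeLa cells (Homo sapiens) for inhibition, read by sulforhodamine B assay; on this read-out higher numbers stand for weaker inhibition and lower numbers for stronger inhibition. Compound 1 `O=C1C=C(NCc2ccccc2)C(=O)c2c1nc1n2[C@H]2OC[C@@H](O)[C@H]2OC1` carries a benzyl group on the amine nitrogen; in this assay compound 1 gives only a limit, > 8000 nM. Compound 3 `O=C1C=C(NC2CCCCC2)C(=O)c2c1nc1n2[C@H]2OC[C@@H](O)[C@H]2OC1` likewise gives only a limit in this assay, > 16000 nM. Hence the step that the two limits leave unreadable from compound 1 to compound 3. For the measured compounds named here, compound 2 `O=C1C(Nc2ccc(Br)cc2)=CC(=O)c2c1nc1n2[C@H]2OC[C@@H](O)[C@H]2OC1` is the sole compound with a number: in this assay compound 2 gives 5220 nM. Compound 4 `O=C1C(Nc2cccc(F)c2)=CC(=O)c2c1nc1n2[C@H]2OC[C@@H](O)[C@H]2OC1` differs from compound 2 in one place: 3-fluorophenyl in place of 4-bromophenyl on an amine nitrogen. Going by the values given here, no measured step exchanges one ring on the amine nitrogen for another, so none bears on this change, and no step beyond the usual scatter is expected in this assay. Compound 4 is therefore expected to give about 6000 nM, between 2500 nM and 20000 nM, an estimated step of a 1.1-fold higher number from compound 2 to compound 4 (0.06 log units; within the scatter).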

Compound 4, half-maximal inhibitory concentration: > 8000 nM
Compound 4 was reported as a limit; the forecaster's own chance of this, stated with the estimate: 30%; at least 1.3-fold (0.12 log units) between middle value and limit.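

In this assay, putting 3-fluorophenyl in place of 4-bromophenyl on this amine nitrogen gives an at least 1.5-fold higher number from compound 2 to compound 4 (0.18 log units; that floor lies within the scatter). The change therefore brings no stronger inhibition that can be seen here. The value of compound 4 is a limit, and the full size of the step stays unknown: the limit of > 8000 nM in this assay, at which 2 of the 4 values shown sit.

The halogen and its place on the ring change together, and the compounds shown do not separate the two. Also open, going by these compounds, is how a phenyl ring carrying an amine or a carboxylic acid would behave on this nitrogen.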